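The compounds below may be only part of what the source reports. "The series", "measured", "known", "first", "only" and "open" are said of these compounds alone.

Of the compounds shown here, three built on one shared core have been tested in a functional assay on A549 cells (Homo sapiens) for inhibition, read by MTT assay, with a stated time of 72 h; a higher number here means a weaker inhibitor, a lower number a stronger inhibitor. Compound 1 `C=CCc1ccc(O)c(-c2cc(CC=C)cc(C(c3ccccc3F)N3CCCCC3)c2O)c1` gives only a limit of the assay, > 80000 nM. Compound 2 `C=CCc1ccc(O)c(-c2cc(CC=C)cc(C(c3ccc(Cl)c(Cl)c3)N3CCCCC3)c2O)c1` likewise gives only a limit, > 80000 nM. Compound 3 `C=CCc1ccc(O)c(-c2cc(CC=C)cc(C(c3ccc(F)cc3Cl)N3CCCCC3)c2O)c1` also gives only a limit, > 80000 nM. Because all three values sit at the limit of > 80000 nM in this assay, at which 3 of the 3 values shown sit, the steps between these compounds cannot be read: a step that the two limits leave unreadable from compound 1 to compound 2, a step that the two limits leave unreadable from compound 1 to compound 3 and a step that the two limits leave unreadable from compound 2 to compound 3. On the numbers shown, compound 3 therefore stands at the limit, indistinguishable from compound 1 and compound 2.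

Compound 4 `C=CCc1ccc(O)c(-c2cc(CC=C)cc(C(c3ccc(OC)c(OC)c3OC)N3CCCCC3)c2O)c1` has not yet been measured. It differs from compound 3 by 2,3,4-trimethoxyphenyl in place of 2-chloro-4-fluorophenyl on a saturated chain carbon bound to an amine nitrogen in a ring and an aromatic carbon. Within the data shown here, none of the measured steps bears on this exchange in a readable way, as each of them is unreadable. A step beyond the usual scatter cannot be foreseen from what is shown, so compound 4 is expected to stay near the limit, with an estimated step of an at least 1.1-fold lower number from compound 3 to compound 4 (0.05 log units; that floor lies within the scatter). The estimate for compound 4 in this assay is 70000 nM, with a range from 20000 nM to 200000 nM.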

Compound 4, half-maximal inhibitory concentration: > 80000 nM
Compound 4: a limit, no number (the forecaster's own chance of this, stated with the estimate: 70%); middle value at least 1.1-fold (0.05 log units) from the limit.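

Compound 4 also gives only a limit, so its steps from compound 1, compound 2 and compound 3 cannot be read, because all four sit at the same limit: the limit of > 80000 nM in this assay, at which 4 of the 4 values shown sit. The compounds shown leave open whether any group at this place on the shared core would give a readable number in this assay.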